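Trading the nitrile for a methoxy on the carbinol ring

This account rests on a few compounds, and the source may have more. Where it says the series, first, only, none or still open, it means among the compounds named here.

Compound 2 `CSc1ccc(COCC#CC(O)c2ccc(C#N)cc2)cc1` gives 41000 nM in an assay on isolated protein for inhibition of Polyunsaturated fatty acid 5-lipoxygenase (Homo sapiens) (a higher number here means a weaker inhibitor, a lower number a stronger inhibitor), the lower of the two numbers obtained. Compound 1 `COc1ccc(C(O)C#CCOCc2ccc(SC)cc2)cc1OC` gives 80000 nM in this assay, a gap that lies within the scatter, so no order between the two can be claimed. Compound 3 `CCCCCC(O)C#CCOCc1ccc(SC)cc1` reaches only a limit of the assay, > 100000 nM, which is the limit of > 100000 nM in this assay, at which 1 of the 3 values shown sits. Compound 4 `COc1ccc(C(O)C#CCOCc2ccc(SC)cc2)cc1` has not yet been measured; it differs from compound 2 in one place, (methoxy in place of cyano on an aromatic carbon). Among the measured compounds shown here, no step between measured compounds is available to anchor this change. Since compound 1, which also carries methoxy on that ring, sits at 80000 nM, the expected step of a 1.5-fold higher number from compound 2 to compound 4 (0.17 log units; within the scatter) is a modest move toward a higher number, hardly beyond the scatter. Compound 4 is therefore estimated at 60000 nM, with a range from 25000 nM to 150000 nM.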

Compound 4, half-maximal inhibitory concentration: > 100000 nM
Compound 4: no number, only a limit (the forecaster's own chance of this, stated with the estimate: 20%); middle value at least 1.6-fold (0.22 log units) from the limit.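

Methoxy in place of cyano gives an at least 2.4-fold higher number from compound 2 to compound 4 (0.38 log units; beyond the scatter), the first step at this position, on an aromatic carbon para to a large group, that passes the scatter, so the nitrile compound is the stronger inhibitor of this pair. The second step, an at least 1.2-fold higher number from compound 1 to compound 4 (0.09 log units; that floor lies within the scatter), sets no order between those two compounds. Compound 4 reaches only a limit of this assay: the limit of > 100000 nM in this assay, at which 2 of the 4 values shown sit.

On these data alone, how far compound 4 lies past that limit stays open. So does whether a carboxylic acid or an amine at this position would give a lower number than the nitrile.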